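Replacing fluoro with sulfamoyl in an antiproliferative compound

The source may hold more compounds than are shown below. What is called first, only, known or untested is meant among the compounds shown, and "the series" means these compounds.

In a functional assay on SF-295 cells (Homo sapiens) for antiproliferative activity, read by sulforhodamine B assay, with a stated time of 72 h (on this read-out higher numbers stand for weaker inhibition and lower numbers for stronger inhibition), compound 1 `S=C(NNc1nncc2ccccc12)Nc1ccccc1` gives 9.5 nM and compound 2 `COc1ccc(NC(=S)NNc2nncc3ccccc23)cc1` gives 7.2 nM. Compound 3 `Fc1ccc(Nc2nncc3ccccc23)cc1` has the lowest number of the three, at 0.43 nM, and so shows the strongest inhibition measured so far. Compound 4 `NS(=O)(=O)c1ccc(Nc2nncc3ccccc23)cc1` has not yet been measured. It differs from compound 3 in one place, with sulfamoyl in place of fluoro on an aromatic carbon, para to a large group (sulfamoyl in place of fluoro on an aromatic carbon).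

Among the measured compounds shown here, only one measured step bears on this change, and only indirectly. Methoxy in place of hydrogen on an aromatic carbon gives a 1.3-fold lower number from compound 1 to compound 2 (0.12 log units; within the scatter). That step stays within the scatter, but it involves a different substituent and two compounds built differently from compound 3. For the measured compounds named here, no measured step removes fluoro or introduces sulfamoyl, so the data offer no direct guide to the size of this step in this assay. Compound 3 already stands at the low end of the numbers, so a moderate rise seems more likely than a further fall.

The expected change is a 3.5-fold higher number from compound 3 to compound 4 (0.54 log units; beyond the scatter), an estimated shift towards weaker inhibition. For compound 4 the estimated value is 1.5 nM, with an expected range from 0.3 nM to 8 nM.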

Compound 4, half-maximal inhibitory concentration: 5.3 nM
For compound 4 the middle estimate is 3.5-fold (0.55 log units) below the measured one, and the stated range covers the measured number.
By their numbers in this assay, from the lowest: compound 3; then compounds 4, 2 and 1 (each within the scatter of the next).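

In this assay, the place para to a large group on the aromatic ring proves sensitive to what it carries: sulfamoyl in place of fluoro gives a 12-fold higher number from compound 3 to compound 4 (1.09 log units; beyond the scatter), a large shift towards weaker inhibition. Among the compounds shown here, this is the first step to lie beyond the scatter, since the only earlier one, methoxy in place of hydrogen, stayed within it and belonged to a differently built pair. The change exchanges 1 heavy atom with no hydrogen-bond donors or acceptors for 4 heavy atoms with 1 hydrogen-bond donor and 2 hydrogen-bond acceptors, but no measurement here explains why the number rises.

As far as these compounds go, it remains open whether the step reflects a gain from fluoro or a loss from sulfamoyl, a question that plain hydrogen at this place on the same core would help to settle. Methylsulfonyl, which keeps the sulfur and both oxygens without the nitrogen, and an amine or a carboxylic acid at this place would show how far the effect extends beyond this one pair.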